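Swapping a cyanophenyl for a methylfuran on a thiazolopyrimidine

The source may hold more compounds than are shown below. What is called first, only, known or untested is meant among the compounds shown, and "the series" means these compounds.

Compound 1 `Nc1nc(-c2ccccc2)nc2sc(-c3ccccc3)nc12` in a functional assay on CHO cells for antagonist activity at adenosine receptor A2b (Homo sapiens), read by cAMP accumulation, with a stated time of 10 min; on this read-out higher numbers stand for weaker inhibition and lower numbers for stronger inhibition — compound 1 gives > 30000 nM, which is a limit of the assay.
Compound 2 `N#Cc1cccc(-c2nc(N)c3nc(-c4ccccc4)sc3n2)c1` — compound 2 gives > 30000 nM, which is also a limit.

The two measured values both sit at the same limit, so a step that the two limits leave unreadable from compound 1 to compound 2 cannot be read, and compound 2 stands only at that limit with no number of its own. The evidence here is the limit of > 30000 nM in this assay, at which 2 of the 2 values shown sit. Compound 3 `Cc1ccc(-c2nc(N)c3nc(-c4ccccc4)sc3n2)o1` differs from compound 2 by 5-methylfuran-2-yl in place of 3-cyanophenyl on an aromatic carbon. Going by the values given here, the one measured step gives no readable size, so it offers no guide to the direction or size of this change. Among the compounds with values here, compound 3 is therefore expected to show a step of an at least 2.0-fold lower number from compound 2 to compound 3 (0.30 log units; that floor lies within the scatter) from compound 2, with the estimate resting only on the single limit that compound 2 shows. Compound 3 is estimated at 15000 nM, within a range of 1000 nM to 30000 nM, in this assay.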

Compound 3, half-maximal inhibitory concentration: > 30000 nM
Compound 3 was reported as a limit; the forecaster's own chance of this, stated with the estimate: 55%; middle value at least 2.0-fold (0.30 log units) away from the limit.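

Compound 3 sits at the same limit as compound 1 and compound 2 in this assay, so no step among the three can be read: the limit of > 30000 nM in this assay, at which 3 of the 3 values shown sit.

The compounds shown leave open whether phenyl, 3-cyanophenyl or 5-methylfuran-2-yl changes inhibition at all, and how strongly any of the three compounds inhibits.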